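The compounds below may be only part of what the source reports. "The series", "measured", "known", "first", "only" and "open" are said of these compounds alone.

Compound 1: `CCOc1ccccc1-c1nnc(SCCn2c([N+](=O)[O-])cnc2C)o1` — 25900 nM
Compound 2: `Cc1ncc([N+](=O)[O-])n1CCSc1nnc(-c2ccc([N+](=O)[O-])cc2)o1` — 12700 nM
Compound 3: `Cc1ncc([N+](=O)[O-])n1CCSc1nnc(-c2ccc(F)cc2)o1` — 8100 nM

Of the compounds shown here, three share a core and have been tested in a functional assay on MCF7 cells (Homo sapiens) for cytotoxicity, read by MTT assay, with a stated time of 48 h; on this read-out higher numbers stand for weaker inhibition and lower numbers for stronger inhibition. Compound 1 gives 25900 nM, compound 2 gives 12700 nM and compound 3 gives 8100 nM. Compound 3 carries the lowest of the three numbers, yet its gap to compound 2 is within the scatter, so the two cannot be ranked; only its gap to compound 1 lies beyond the scatter. Going by the values given here, the one single-point step recorded is a 1.6-fold lower number from compound 2 to compound 3 (0.20 log units; within the scatter).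

Compound 4, `Cc1ncc([N+](=O)[O-])n1CCSc1nnc(-c2ccc(N)nc2)o1`, has not yet been measured in this assay. It differs from compound 3 in one place: 6-aminopyridin-3-yl in place of 4-fluorophenyl on an aromatic carbon. Among the compounds with values here, no measured pair shows this exchange, and the only step seen at this position, the step from nitro to fluoro, stayed within the scatter. There is thus no ground in the data for a shift in either direction, and the expectation is a step from compound 3 to compound 4 that stays within the scatter, a 1.2-fold higher number from compound 3 to compound 4 (0.09 log units; within the scatter). Compound 4 is estimated at 10000 nM, with a range from 4000 nM to 30000 nM.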

Compound 4, half-maximal inhibitory concentration: 26800 nM
The estimate for compound 4 lay 2.7-fold (0.43 log units) below the measured number; the range from low to high includes it.
By their numbers in this assay, from the lowest: compounds 3 and 2 (each within the scatter of the next); then compounds 1 and 4 (each within the scatter of the next).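

In this assay, this position on the shared core, an aromatic carbon of the five-membered aromatic ring, responds to a change of the whole aryl group: 6-aminopyridin-3-yl in place of 4-fluorophenyl gives a 3.3-fold higher number from compound 3 to compound 4 (0.52 log units; beyond the scatter), a modest step, while the exchange of nitro for fluoro on the aryl ring gave only a 1.6-fold lower number from compound 2 to compound 3 (0.20 log units; within the scatter). This exchange alters the ring and its substituent together: a ring of carbon only gives way to one with a hetero atom, and a group with no hydrogen-bond donors or acceptors gives way to one that has both, so the compounds shown cannot assign the step to any single part of the change. Nothing available here bears on the reason for this step.

From the compounds shown here alone, what remains open is whether the ring nitrogen or the amine accounts for the step, a question that a plain pyridin-3-yl group and a 4-aminophenyl group at this position could separate. Going by these compounds, it is also open whether an acetamide in place of the amine would keep, recover or further change the number seen for compound 4.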